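This account rests on a few compounds, and the source may have more. Where it says the series, first, only, none or still open, it means among the compounds named here.

Compound 2 `CC1CCN(c2ccc3cc(NC(=O)CCc4ccc(C(F)(F)F)cc4)ccc3n2)C1` is measured in a functional assay on HEK293 cells for activation of melanin-concentrating hormone receptor 1 (Rattus norvegicus), read by inositol phosphate accumulation (a higher number here means that more compound is needed for the effect, a lower number that less compound is needed), where compound 2 gives 400 nM. Among the measured compounds shown here, of the two numbers known so far this is the higher one; compound 1 `O=C(CCc1ccc(C(F)(F)F)cc1)Nc1ccc2nc(N3CCC(NS(=O)(=O)O)C3)ccc2c1` gives 50 nM, and the only measured step, an 8.0-fold higher number from compound 1 to compound 2 (0.90 log units; beyond the scatter), separates them. Compound 3 `O=C(CCc1ccc(C(F)(F)F)cc1)Nc1ccc2nc(N3CCC(c4ccccc4)C3)ccc2c1` differs from compound 2 by phenyl in place of methyl on a saturated ring carbon. For the measured compounds named here, no measured step bears directly on this change: the single known step concerns a sulfoamino group giving way to methyl at the same saturated ring carbon and says nothing about methyl giving way to phenyl. Compound 2 is thus the only anchor, and both the size and the direction of the coming step are open. The estimate for compound 3 is 400 nM, with a range from 80 nM to 2000 nM. This corresponds to an expected step of no change at the digits printed from compound 2 to compound 3 (within the scatter), essentially no change beyond the scatter, held with wide uncertainty.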

Compound 3, half-maximal effective concentration: 1770 nM
Beside the measured number, compound 3's estimate is 4.4-fold (0.65 log units) below it; the measured number falls inside the stated range.
By their numbers in this assay, from the lowest: compound 1; then compound 2; then compound 3.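

Putting phenyl in place of methyl on this saturated ring carbon gives a 4.4-fold higher number from compound 2 to compound 3 (0.65 log units; beyond the scatter) in this assay, so the position responds to a change between two groups made only of carbon and hydrogen, not just to the loss of sulfoamino. Replacing sulfoamino with phenyl gives a 35-fold higher number from compound 1 to compound 3 (1.55 log units; beyond the scatter), a larger step than the one to methyl, so among these three compounds the number rises from sulfoamino to methyl to phenyl. Nothing available explains why these numbers rise.

The compounds shown leave open whether the rise from methyl to phenyl follows from the ring itself or would also appear with a longer chain such as butyl, or with a saturated cyclohexyl ring. They also leave open whether an amine or a carboxylic acid on this carbon would give a number as low as that of sulfoamino.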